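Aryl substituent exchange and whole-organism inhibition

The source may hold more compounds than are shown below. What is called first, only, known or untested is meant among the compounds shown, and "the series" means these compounds.

Measured so far in a functional assay on the whole organism with Rattus norvegicus as the target, at a dose of 20 mg/kg by the intraperitoneal route; on this read-out higher numbers stand for more inhibition at the one dose given (going by the name of the read-out) and lower numbers for less inhibition:
compound 1 `COc1ccc(Br)cc1-c1nc(N)nc(N)n1` gives 49%
compound 2 `CS(=O)(=O)c1cccc(-c2nc(N)nc(N)n2)c1` gives -6%
compound 3 `Nc1nc(N)nc(-c2cc(Br)ccc2F)n1` gives 100%

Compound 2 stands lowest of the three; compound 1 sits above it and compound 3 furthest above, both gaps beyond the scatter. Compound 4 `Nc1nc(N)nc(-c2cccc(C(F)(F)F)c2)n1` differs from compound 2 by trifluoromethyl in place of methylsulfonyl on an aromatic carbon. Going by the values given here, the only measured single-point step, a number 51 percentage points higher from compound 1 to compound 3 (beyond the scatter), exchanges a different pair of groups and bears on this change only loosely; no measured step exchanges methylsulfonyl for trifluoromethyl. Since compound 2 gives -6% while compound 1 gives 49% and compound 3 gives 100%, a rise of a number 46 percentage points higher from compound 2 to compound 4 (beyond the scatter) in this assay is expected, with wide uncertainty. Compound 4 is estimated at 40%, between -5% and 85%.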

Compound 4, a percentage reported as inhibition, in the whole organism at one dose (the size of the read-out at that dose, not a potency): 81%
Beside the measured number, compound 4's estimate is 41 percentage points below it, and the stated range covers the measured number.
By their numbers in this assay, from the lowest: compound 2; then compound 1; then compound 4; then compound 3.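

The exchange gives a number 87 percentage points higher from compound 2 to compound 4 (beyond the scatter) in this assay at this aromatic carbon, so a change at this one place can carry a large difference in the read-out. It removes the hydrogen-bond acceptors and the double bonds of methylsulfonyl while the heavy-atom count stays the same. No measurement at hand gives a reason for the step.

Going by these compounds, whether an amine, a carboxylic acid or a nitrile at this carbon would read nearer compound 2 or compound 4 stays open. Also open, on these data alone, is whether the exchange carries the same size with bromo on the ring.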